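Chloro for Fluoro: Expected Potency of Compound 3

This account rests on a few compounds, and the source may have more. Where it says the series, first, only, none or still open, it means among the compounds named here.

For the measured compounds named here, compound 1 `CCn1c(CNc2ccccc2)nnc1SCC(=O)Nc1ccc(C(=O)OC)cc1` is the one member of the pair with a number: in an assay on isolated protein for inhibition of long-chain fatty acid transport protein 1 (Homo sapiens) (a lower number here means a stronger inhibitor, a higher number a weaker inhibitor), compound 1 gives 540 nM. Compound 2 `CCn1c(CNc2ccccc2)nnc1SCc1nc2cc(F)ccc2o1` stands at the weak end of what is shown. In this assay compound 2 gives > 1000 nM, which is a limit of the assay rather than a number, as recorded in the limit of > 1000 nM in this assay, at which 1 of the 2 values shown sits. Compound 3 `CCn1c(CNc2ccccc2)nnc1SCc1nc2cc(Cl)ccc2o1` differs from compound 2 by chloro in place of fluoro on an aromatic carbon. Going by the values given here, no measured step covers this change, so the expected step in this assay is a step that the limit leaves unreadable from compound 2 to compound 3, not beyond the scatter. Compound 3 is therefore expected at 1500 nM, with a range from 500 nM to 5000 nM in this assay.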

Compound 3, half-maximal inhibitory concentration: > 1000 nM
Compound 3 ended at the assay's limit; the forecaster's own chance of this, stated with the estimate: 60%; the middle value lies beyond the limit too.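

No step can be read from compound 2 to compound 3, as both stand at a limit of this assay: the limit of > 1000 nM in this assay, at which 2 of the 3 values shown sit.

The compounds shown leave open whether chloro and fluoro on the shared core differ at all in this assay.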